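The source may report more compounds than this note shows. Statements on the series, on what has been measured and on what is new or still open speak of the compounds shown alone.

Working notes on the series built on the core of compound 1 `CCCCCCCCCCCCCCNC(=O)[C@H](CO)/N=C/c1cccc(OC)c1`, read in an ADME assay on HEK293 cells (Homo sapiens) for cytotoxicity; on this read-out lower numbers stand for stronger inhibition and higher numbers for weaker inhibition. Here compound 1 gives 77300 nM, compound 2 `CCCCCCCCCCCCCCNC(=O)[C@H](CO)/N=C/c1ccccc1Cl` gives 94900 nM and compound 3 `CCCCCCCCCCCCCCNC(=O)[C@H](CO)/N=C/c1ccccc1O` gives 80800 nM. Compound 3 therefore stands within the scatter of both other compounds, and no order can be drawn among the three.

The next compound is compound 4 `CCCCCCCCCCCCCCNC(=O)[C@H](CO)/N=C/c1ccc(Cl)cc1`. The change from compound 3 is 4-chlorophenyl in place of 2-hydroxyphenyl on a carbon with a double bond to nitrogen. Within the data shown here, three measured steps bear on it. Closest is the exchange of hydroxy for chloro on an aromatic carbon, a 1.2-fold lower number from compound 2 to compound 3 (0.07 log units; within the scatter). The exchanges at the same carbon with a double bond to nitrogen are a 1.2-fold higher number from compound 1 to compound 2 (0.09 log units; within the scatter) and a 1.0-fold higher number from compound 1 to compound 3 (0.02 log units; within the scatter). All three lie within the scatter, so neither the aryl groups tried so far nor their substituents have moved the number in this assay. Among the measured compounds shown here, no measured compound carries the 4-chlorophenyl group, so that group itself remains untested, and the evidence rests on only three compounds.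

No step beyond the scatter is expected in this assay. The expected step is a 1.1-fold higher number from compound 3 to compound 4 (0.02 log units; within the scatter). For compound 4 the estimated value is 85000 nM, with an expected range of 50000 nM to 140000 nM.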

Compound 4, half-maximal inhibitory concentration: 77700 nM
For compound 4 the middle estimate is 1.1-fold (0.04 log units) above the measured one; low and high end bracket the measured number.
By their numbers in this assay, from the lowest: compounds 1, 4, 3 and 2 (each within the scatter of the next).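

In this assay, among these compounds, the chlorine-bearing pair gives the first direct comparison of one substituent in two placements on the aryl group, and 4-chlorophenyl in place of 2-chlorophenyl stays within the scatter (a 1.2-fold lower number from compound 2 to compound 4 (0.09 log units; within the scatter)). The change from 2-hydroxyphenyl, with 1 hydrogen-bond donor and 1 hydrogen-bond acceptor, to 4-chlorophenyl, with 0 of each, also leaves the number within the scatter (a 1.0-fold lower number from compound 3 to compound 4 (0.02 log units; within the scatter)), as does 4-chlorophenyl in place of 3-methoxyphenyl (a 1.0-fold higher number from compound 1 to compound 4 (0.00 log units; within the scatter)), so all four aryl groups on the carbon with a double bond to nitrogen now read alike here. No measurement at hand offers an explanation for this flat reading.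

Still open, on these data alone, is whether an aryl group carrying an amine or a carboxylic acid on the same carbon would give a step beyond the scatter in this assay. Equally open, as far as these compounds go, is whether a shorter chain on the amide nitrogen of the shared core would move the number when the aryl group is held constant.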